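Carbamoylmethyl in place of 1-hydroxyethyl: compound 4

The source may report more compounds than this note shows. Statements on the series, on what has been measured and on what is new or still open speak of the compounds shown alone.

Three compounds built on the shared core of compound 1 have been tested in a functional assay on the whole organism (Tail, strain ICR) with Mus musculus as the target, in the tail flick test, with a stated time of 60 min, at a dose of 25 umol/kg by the oral route; a lower number here means a weaker effect, a higher number a stronger effect of the compound at the dose given. Compound 1 `C[C@@H](O)[C@H](NC(=O)CN(c1nc(Cl)nc2[nH]cnc12)C1CC1)C(=O)OCc1ccccc1` gives 29.7%. Compound 2 `O=C(O)CNC(=O)CN(c1nc(Cl)nc2[nH]cnc12)C1CC1` gives 38.9%, and compound 3 `C[C@@H](O)[C@H](NC(=O)CN(c1nc(Cl)nc2[nH]cnc12)C1CC1)C(=O)O` gives 30.1%. Compound 1 holds the lowest of the three numbers, yet the step of a number 0.4 percentage points higher from compound 1 to compound 3 (within the scatter) and the step of a number 8.8 percentage points lower from compound 2 to compound 3 (within the scatter) both stay within the scatter, so no order among the three is supported by these data.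

Compound 4 `NC(=O)C[C@H](NC(=O)CN(c1nc(Cl)nc2[nH]cnc12)C1CC1)C(=O)OCc1ccccc1` differs from compound 1 in one place: carbamoylmethyl in place of 1-hydroxyethyl on a saturated chain carbon bound to an amide-type nitrogen and a carbonyl carbon. Among the measured compounds shown here, the only measured step touching that same place is the one from compound 2 to compound 3, which exchanged hydrogen for 1-hydroxyethyl and stayed within the scatter; the step from compound 1 to compound 3 concerns the ester oxygen and does not bear on it. Nothing in the series therefore points to a change beyond the scatter for this exchange. The expected step of a number 0.3 percentage points higher from compound 1 to compound 4 (within the scatter) is small. Compound 4 is estimated at 30%, with a range from 18% to 44%.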

Compound 4, a percentage reported as activity, at one dose (the size of the read-out at that dose, not a potency): 36.4%
Compound 4: the middle estimate sits 6.4 percentage points below what was measured, within the range that was stated.
By their numbers in this assay, from the lowest: compounds 1, 3, 4 and 2 (each within the scatter of the next).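

In this assay, the exchange on the saturated chain carbon bound to an amide-type nitrogen and a carbonyl carbon gives a number 6.7 percentage points higher from compound 1 to compound 4 (within the scatter). Among the compounds shown here, this place therefore accepts carbamoylmethyl, with its nitrogen and its double bond outside aromatic rings, without a step beyond the scatter, and this is the first exchange here read with the benzyl ester kept in place. Together with the earlier exchange of hydrogen for 1-hydroxyethyl, two different changes at this carbon now stay within the scatter, and no data on hand explain the size of either step.

Open, on these data alone, is whether an aminoethyl group, a carboxymethyl group or a longer alkyl chain on this carbon would give a step beyond the scatter. Also open, as far as these compounds go, is how carbamoylmethyl reads with a free carboxylic acid in place of the benzyl ester.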